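The source may report more compounds than this note shows. Statements on the series, on what has been measured and on what is new or still open speak of the compounds shown alone.

Within the data shown here, compound 2 `CN1CCN(CCCn2c3c(c4ccccc42)C(=O)c2c[n+]([O-])c4ccccc4c2C3=O)CC1` is the higher of the two numbers measured so far: in a functional assay on A-375 cells (Homo sapiens) for cytotoxicity, read by MTT assay, with a stated time of 72 h (on this read-out higher numbers stand for weaker inhibition and lower numbers for stronger inhibition), compound 2 gives 470 nM, while compound 1 `O=C1c2c[n+]([O-])c3ccccc3c2C(=O)c2c1c1ccccc1n2CCCCn1ccnc1` gives 350 nM, a gap of a 1.3-fold higher number from compound 1 to compound 2 (0.13 log units; within the scatter) that means nothing beyond repeat-to-repeat variation.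

Compound 3 `O=C1c2c[n+]([O-])c3ccccc3c2C(=O)c2c1c1ccccc1n2Cc1cn(C[C@@H](O)CO)nn1` changes the same chain again, this time more deeply: 1-(2,3-dihydroxypropyl)-1H-1,2,3-triazol-4-yl in place of 2-(4-methylpiperazin-1-yl)ethyl on a saturated chain carbon bound to an aromatic nitrogen.

Among the measured compounds shown here, only the step from compound 1 to compound 2 bears on this change, and it was small. The new group is far larger in kind, so a modest weakening is expected, a 1.4-fold higher number from compound 2 to compound 3 (0.14 log units; within the scatter). Compound 3 is therefore estimated at 650 nM, in a range from 250 nM to 1700 nM.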

Compound 3, half-maximal inhibitory concentration: 140 nM
Compound 3: middle estimate off by 4.6-fold (0.67 log units), on the high side, outside the stated range (below it).
By their numbers in this assay, from the lowest: compound 3; then compounds 1 and 2 (each within the scatter of the next).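

In this assay, the 1-(2,3-dihydroxypropyl)-1H-1,2,3-triazol-4-yl group moves the number beyond the scatter against both earlier side chains (a 3.4-fold lower number from compound 2 to compound 3 (0.53 log units; beyond the scatter); a 2.5-fold lower number from compound 1 to compound 3 (0.40 log units; beyond the scatter)). The earlier swap between the two amine-type rings had shown no such separation, so the side chain at this position can matter for cytotoxicity. Nothing measured here accounts for the gain.

The triazole ring and the dihydroxypropyl part enter together, so their shares stay unresolved. A triazole carrying a plain propyl chain, or a carboxylic acid in place of the two hydroxyl groups, would begin to separate them.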